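The source may hold more compounds than are shown below. What is called first, only, known or untested is meant among the compounds shown, and "the series" means these compounds.

Measured compounds: compound 1 `COc1ccc(Cl)cc1S(=O)(=O)Nc1cncc(C(=O)Nc2ccccc2)c1`, with "not determined" (no result reported) in an assay on isolated protein for inhibition of alkaline phosphatase, tissue-nonspecific isozyme (Homo sapiens); on this read-out lower numbers stand for stronger inhibition and higher numbers for weaker inhibition; compound 2 `COc1ccc(Cl)cc1S(=O)(=O)Nc1cncc(-c2ccncc2)c1`, which in this assay sits at the limit > 20000 nM, a limit and not a number; compound 3 `COc1ccc(Cl)cc1S(=O)(=O)Nc1cncc(C(N)=O)c1`, which in this assay gives 105 nM.

Compound 3 holds the only single number shown; the others are a limit or no result. Going by the values given here, the sole measured step, an at least 190-fold lower number from compound 2 to compound 3 (2.27 log units; beyond the scatter), concerns the group on the aromatic carbon, not the carbonyl. Compound 4 `COC(=O)c1cncc(NS(=O)(=O)c2cc(Cl)ccc2OC)c1` differs from compound 3 by methoxy in place of amino on a carbonyl carbon. Among the compounds with values here, no measured step alters the carbonyl substituent, so the expectation rests on the change alone. A modest weakening, a 3.8-fold higher number from compound 3 to compound 4 (0.58 log units; beyond the scatter), is expected. Compound 4 is estimated at 400 nM in this assay, within 100 nM to 2000 nM.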

Compound 4, half-maximal inhibitory concentration: > 20000 nM
Compound 4 was reported as a limit; the forecaster's own chance of this, stated with the estimate: 5%; middle value at least 50-fold (1.69 log units) away from the limit.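

In this assay, the carbonyl substituent now has a measured step of its own: methoxy in place of amino on a carbonyl carbon gives an at least 190-fold higher number from compound 3 to compound 4 (2.27 log units; beyond the scatter). Going by these compounds alone, the earlier compounds changed only the group on the aromatic carbon, so this is the first sign that the amino on the carbonyl carbon matters. The carbonyl alone does not suffice, and compound 4 is reported only as a limit: the limit of > 20000 nM in this assay, at which 2 of the 4 values shown sit.

The step between the two compounds at this limit cannot be read. Going by these compounds, whether a methylamine amide or a carboxylic acid on the same carbonyl carbon would stay close to compound 3 remains open.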